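A few compounds are considered here, and "the series" means these few. Any claim that something is new, unique, unknown or untested is made for them only; others in the source may bear on it.

Compound 3 `CCCCCCCCCCCCCCCCCCNC(=O)[C@H]1CSC(c2ccc(C#N)cc2)N1` gives in a functional assay on TSU-Pr1 cells for antiproliferative activity against TSU (Homo sapiens), read by sulforhodamine B assay (a lower number here means a stronger inhibitor, a higher number a weaker inhibitor), only a limit of the assay, > 20000 nM; this is the limit of > 20000 nM in this assay, at which 1 of the 3 values shown sits. Compound 1 `CCCCCCCCCCCCCCCCCCNC(=O)[C@H]1CSC(CCCCCCCCCCCC)N1` gives 10700 nM, and compound 2 `CCCCCCCCCCCCCCCCCCNC(=O)[C@H]1CSC(c2ccc(F)cc2)N1` gives 5400 nM. The step of an at least 3.7-fold higher number from compound 2 to compound 3 (0.56 log units; beyond the scatter) lay beyond the scatter, while an at least 1.8-fold higher number from compound 1 to compound 3 (0.27 log units; that floor lies within the scatter) did not reach it. Compound 4 `CCCCCCCCCCCCCCCCCCNC(=O)[C@H]1CSC(c2cc(F)cc(F)c2)N1` arises from compound 3 by 3,5-difluorophenyl in place of 4-cyanophenyl on a saturated ring carbon. Among the measured compounds shown here, two measured steps bear on this change: a 2.0-fold lower number from compound 1 to compound 2 (0.30 log units; within the scatter) and an at least 3.7-fold higher number from compound 2 to compound 3 (0.56 log units; beyond the scatter), the second of which is undone in part, since a nitrile leaves and fluorine enters. Compound 4 is therefore expected to land near compound 2, a step of an at least 2.8-fold lower number from compound 3 to compound 4 (0.45 log units; beyond the scatter). The estimate for compound 4 is 7000 nM, with a range from 3000 nM to 20000 nM.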

Compound 4, half-maximal inhibitory concentration: > 20000 nM
Compound 4 ended at the assay's limit; the forecaster's own chance of this, stated with the estimate: 20%; middle value at least 2.8-fold (0.45 log units) away from the limit.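

Putting 3,5-difluorophenyl in place of 4-fluorophenyl on this saturated ring carbon weakens activity in this assay, giving an at least 3.7-fold higher number from compound 2 to compound 4 (0.56 log units; beyond the scatter), so losing the nitrile does not by itself recover the level of compound 2. Against the dodecyl group, the change gives an at least 1.8-fold higher number from compound 1 to compound 4 (0.27 log units; that floor lies within the scatter). The step between compound 3 and compound 4 cannot be read, because both values are limits of the assay: the limit of > 20000 nM in this assay, at which 2 of the 4 values shown sit.

On these data alone, how far compound 3 and compound 4 lie beyond that limit stays open. So does whether an amine or a carboxylic acid on the phenyl ring would give a lower number than compound 2.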